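A changed chain on compound 3

The source may hold more compounds than are shown below. What is called first, only, known or untested is meant among the compounds shown, and "the series" means these compounds.

Values in an ADME assay on HEK293 cells (Homo sapiens) for cytotoxicity, read by MTT assay, with a stated time of 48 h (a lower number here means a stronger inhibitor, a higher number a weaker inhibitor), follow
compound 1 `CCN(CC)CCn1c(N)c(-c2nc3ccccc3[nH]2)c2nc(C#N)c(C#N)nc21` gives 12200 nM
compound 2 `CN(C)CCCCn1c(N)c(-c2nc3ccccc3n2C)c2nc(C#N)c(C#N)nc21` gives 3870 nM
compound 3 `CCN(CC)CCn1c(N)c(-c2nc3cc(Cl)ccc3[nH]2)c2nc(C#N)c(C#N)nc21` gives > 50000 nM as a limit

Compound 3 sits at the limit of > 50000 nM in this assay, at which 1 of the 3 values shown sits, and so has no exact number. Compound 4 `CN(C)CCCCn1c(N)c(-c2nc3cc(Cl)ccc3[nH]2)c2nc(C#N)c(C#N)nc21` is not yet measured and differs from compound 3 thus: 2-(dimethylamino)ethyl in place of diethylamino on a saturated chain carbon, two bonds along the chain from an aromatic nitrogen, which is 2-(dimethylamino)ethyl in place of diethylamino on a saturated chain carbon, two bonds along the chain from an aromatic nitrogen. Among the measured compounds shown here, the one measured step, an at least 4.0-fold higher number from compound 1 to compound 3 (0.61 log units; beyond the scatter), brings in the chloro that compound 4 keeps. For the measured compounds named here, no measured step isolates the chain change. Compound 2 carries the 4-(dimethylamino)butyl chain and differs from compound 1 in more than that chain. Compound 1 gives 12200 nM and compound 2 gives 3870 nM in this assay. So a lower number than the limit of compound 3 is expected for compound 4. The expected size is an at least 3.1-fold lower number from compound 3 to compound 4 (0.49 log units; beyond the scatter) as an estimate. For compound 4 the estimated value is 16000 nM, with an expected range of 5000 nM to 50000 nM.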

Compound 4, half-maximal inhibitory concentration: 4730 nM
Compound 4: middle estimate off by 3.4-fold (0.53 log units), on the high side; measured number outside the range, below it.
By their numbers in this assay, from the lowest: compounds 2 and 4 (each within the scatter of the next); then compound 1. At a limit, above all of these: compound 3.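

In this assay, among the compounds shown here, the chain change on a saturated chain carbon, two bonds along the chain from an aromatic nitrogen, gives an at least 10-fold lower number from compound 3 to compound 4 (1.02 log units; beyond the scatter), a large step that no earlier pair isolated. Compound 3 has a limit and not an exact number: the limit of > 50000 nM in this assay, at which 1 of the 4 values shown sits. With the 4-(dimethylamino)butyl chain on both compounds, the swap to 5-chloro-1H-benzimidazol-2-yl from 1-methyl-1H-benzimidazol-2-yl gives a 1.2-fold higher number from compound 2 to compound 4 (0.09 log units; within the scatter), so these two compounds do not separate. The compounds shown leave open whether the chain change carries the same size without the chloro, and how a longer chain or a piperidine in place of the dimethylamino end would read.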